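A few compounds are considered here, and "the series" means these few. Any claim that something is new, unique, unknown or untested is made for them only; others in the source may bear on it.

In a functional assay, tested at 2.5 mM (on this read-out higher numbers stand for more inhibition at the one concentration tested (going by the name of the read-out) and lower numbers for less inhibition), compound 1 `CSCC[C@@H]1NC(=O)[C@H](CC(C)C)NC1=O` gives 0%. Compound 2 `CC(C)C[C@@H]1NC(=O)[C@H](CC(N)=O)NC1=O`, in which carbamoyl replaces (methylsulfanyl)methyl on a saturated chain carbon bound to a saturated ring carbon, gives 0% in this assay. The step of no change at the digits printed from compound 1 to compound 2 (within the scatter) is flat, so compound 2 stands level with compound 1 at the digits shown, and compound 1 is its only measured neighbour.

Compound 3 `CC(C)C[C@@H]1NC(=O)[C@H](Cc2cnc[nH]2)NC1=O` is not yet measured. It differs from compound 2 by 1H-imidazol-5-yl in place of carbamoyl on a saturated chain carbon bound to a saturated ring carbon. For the measured compounds named here, no measured step covers this exchange. Going by the values given here, the only step in hand, no change at the digits printed from compound 1 to compound 2 (within the scatter), shows that an exchange at the same place left the read-out flat, with both compounds at the bottom of the scale, so nothing different is expected here. The expected step is no change at the digits printed from compound 2 to compound 3 (within the scatter), nothing beyond the scatter. Compound 3 is estimated at 0%, with a range from -10% to 15%.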

Compound 3, a percentage reported as inhibition, at one concentration (the size of the read-out at that concentration, not a potency): 0%
Compound 3: middle estimate and measured number agree at the digits printed; low and high end bracket the measured number.
By their numbers in this assay, from the lowest: compounds 1, 2 and 3 (each within the scatter of the next).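

In this assay the exchange of carbamoyl for 1H-imidazol-5-yl on a saturated chain carbon bound to a saturated ring carbon gives no change at the digits printed from compound 2 to compound 3 (within the scatter) and the exchange of (methylsulfanyl)methyl for the same group gives no change at the digits printed from compound 1 to compound 3 (within the scatter) on this read-out. This place has now carried a five-membered aromatic ring with 2 hetero atoms as well as two open-chain groups, and compound 3 at 0% adds an aromatic ring to the changes that leave the read-out level. No available evidence bears on this flat result.

Going by these compounds, whether an amine, a carboxylic acid or a longer chain at this place would lift the read-out from this level stays open. For the compounds shown here, with all three compounds level, the series so far holds no measured step beyond the scatter to work from.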